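Adding a Cyclopropyl to the Oxadiazole Chain of Compound 3

The source may hold more compounds than are shown below. What is called first, only, known or untested is meant among the compounds shown, and "the series" means these compounds.

In an ADME assay on MDCKII-LE cells (Canis lupus familiaris) for permeability (on this read-out lower numbers stand for lower permeability and higher numbers for higher permeability), compound 1 `N#CCCCN([C@H](CCC(F)(F)F)C(N)=O)S(=O)(=O)c1ccc(Cl)cc1` reads 27.6 10^-6 cm/s and compound 2 `N#CC1(CN([C@H](CCC(F)(F)F)C(N)=O)S(=O)(=O)c2ccc(Cl)cc2)CC1` reads 29.9 10^-6 cm/s while compound 3 `NC(=O)[C@@H](CCC(F)(F)F)N(CCCc1ncon1)S(=O)(=O)c1ccc(Cl)cc1` reads 31.3 10^-6 cm/s and so stands level with both, all three within the scatter. Compound 4 `NC(=O)[C@@H](CCC(F)(F)F)N(CC1(c2ncon2)CC1)S(=O)(=O)c1ccc(Cl)cc1` has not yet been measured. What separates it from compound 3 is 1-(1,2,4-oxadiazol-3-yl)cyclopropyl in place of 2-(1,2,4-oxadiazol-3-yl)ethyl on a saturated chain carbon bound to a sulfonamide nitrogen on a saturated chain carbon bound to a sulfonamide nitrogen. The nearest measured parallel is the same exchange carrying a nitrile (a 1.1-fold higher number from compound 1 to compound 2 (0.03 log units; within the scatter)) and it stayed within the scatter. Exchanging nitrile for 1,2,4-oxadiazol-3-yl (a 1.1-fold higher number from compound 1 to compound 3 (0.05 log units; within the scatter)) also stayed within it. No step beyond the scatter is therefore expected in this assay here. The expected change is a 1.0-fold higher number from compound 3 to compound 4 (0.01 log units; within the scatter) and thus small. Compound 4 is expected at 32 10^-6 cm/s with an estimated range from 21 10^-6 cm/s to 47 10^-6 cm/s on measurement.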

Compound 4, apparent permeability: 16.4 10^-6 cm/s
Compound 4: middle estimate off by 2.0-fold (0.29 log units), on the high side; the measured number lies below the stated range.
By their numbers in this assay, from the lowest: compounds 4, 1, 2 and 3 (each within the scatter of the next).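

In this assay, the cyclopropyl on the oxadiazole chain gives a 1.9-fold lower number from compound 3 to compound 4 (0.28 log units; within the scatter), and 1,2,4-oxadiazol-3-yl in place of cyano on a saturated ring carbon gives a 1.8-fold lower number from compound 2 to compound 4 (0.26 log units; within the scatter). Among these compounds, the third new step, a 1.7-fold lower number from compound 1 to compound 4 (0.23 log units; within the scatter), is of similar size, so all three exceed the earlier steps in size, yet none leaves the scatter. Nothing measured here accounts for the size of these steps.

Going by these compounds, whether a cyclobutyl or a gem-dimethyl carbon in place of the cyclopropyl would give a step beyond the scatter remains open.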